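Trading a Chlorine for Hydrogen on a Shared Core

The source may hold more compounds than are shown below. What is called first, only, known or untested is meant among the compounds shown, and "the series" means these compounds.

Compound 1 `CC(C)COC(=O)Nc1ccc([Se]C#N)cc1`: 51200 nM
Compound 2 `N#C[Se]c1ccc(NC(=O)Oc2ccc(Cl)cc2)cc1`: 41400 nM

Two measured compounds share a core that ends in a carbamate. In a functional assay on HTB-54 cells (Homo sapiens) for cytotoxicity, read by MTT assay, with a stated time of 72 h (a lower number here means a stronger inhibitor of growth, a higher number a weaker inhibitor of growth), compound 1 gives 51200 nM. In this assay compound 2 gives 41400 nM, a number that sits within the scatter of compound 1. Compound 3 `N#C[Se]c1ccc(NC(=O)Oc2ccccc2)cc1` differs from compound 2 by hydrogen in place of chloro on an aromatic carbon. Going by the values given here, no pair of measured compounds shows what this change does, so no shift beyond the scatter is expected in either direction. Compound 3 is expected to give about 50000 nM, from 20000 nM to 120000 nM. The step of a 1.2-fold higher number from compound 2 to compound 3 (0.08 log units; within the scatter) is estimated to remain within the scatter.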

Compound 3, concentration for total growth inhibition: 50200 nM
For compound 3 the middle estimate is 1.0-fold (0.00 log units) below the measured one; low and high end bracket the measured number.
By their numbers in this assay, from the lowest: compounds 2, 3 and 1 (each within the scatter of the next).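

In this assay, going by these compounds alone, hydrogen in place of chloro on the aromatic carbon gives a 1.2-fold higher number from compound 2 to compound 3 (0.08 log units; within the scatter), the first direct reading of this change at this position. Phenyl in place of isobutyl on an oxygen next to a carbonyl group gives a 1.0-fold lower number from compound 1 to compound 3 (0.01 log units; within the scatter), so neither single change moves the number beyond the scatter. Nothing available here gives a reason for either result. These two steps cover only chloro and hydrogen at one position and two groups on the oxygen. On these data alone, whether an amine at this position, or a longer chain on the oxygen, would shift the number beyond the scatter stays open.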